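This account rests on a few compounds, and the source may have more. Where it says the series, first, only, none or still open, it means among the compounds named here.

Measured in (a functional assay on A549 cells (Homo sapiens) for antiproliferative activity, read by MTT assay, with a stated time of 48 h; on this read-out lower numbers stand for stronger inhibition and higher numbers for weaker inhibition)
- Compound 1 (`CCN(CC)CCCn1c(N)c(-c2nc3ccccc3[nH]2)c2nc(C#N)c(C#N)nc21`) gives (25300 nM)
- Compound 2 (`CN1CCN(CCCn2c(N)c(-c3nc4ccccc4[nH]3)c3nc(C#N)c(C#N)nc32)CC1`) gives (5750 nM)
- Compound 3 (`CCN(CC)CCCCn1c(N)c(-c2nc3ccccc3[nH]2)c2nc(C#N)c(C#N)nc21`) gives (5750 nM)

Compound 3 and compound 2 share the lowest number of the three (no change at the digits printed from compound 2 to compound 3 (within the scatter)), and compound 1 stands higher (a 4.4-fold lower number from compound 1 to compound 3 (0.64 log units; beyond the scatter)). Compound 4 (`CCN(CC)CCCCn1c(N)c(-c2nc3cc(Cl)ccc3[nH]2)c2nc(C#N)c(C#N)nc21`) carries chloro in place of hydrogen on an aromatic carbon, so that 1H-benzimidazol-2-yl becomes 5-chloro-1H-benzimidazol-2-yl (chloro in place of hydrogen on an aromatic carbon). For the measured compounds named here, no measured step touches this aromatic ring, as all of them sit on the saturated chain. Going by the values given here, the only guide to size is therefore the modest chain steps (a 4.4-fold lower number from compound 1 to compound 2 (0.64 log units; beyond the scatter)) and (a 4.4-fold lower number from compound 1 to compound 3 (0.64 log units; beyond the scatter)), and they give no direction for this change. A modest move to a lower number is expected (a 1.9-fold lower number from compound 3 to compound 4 (0.28 log units; within the scatter)). For compound 4 the estimated value is (3000 nM), with an expected range from (1000 nM) to (9000 nM).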

Compound 4, half-maximal inhibitory concentration: 2270 nM
Beside the measured number, compound 4's estimate is 1.3-fold (0.12 log units) above it; the range from low to high includes it.
By their numbers in this assay, from the lowest: compound 4; then compounds 2 and 3 (each within the scatter of the next); then compound 1.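

In this assay, for the compounds shown here, chloro in place of hydrogen on an aromatic carbon gives a 2.5-fold lower number from compound 3 to compound 4 (0.40 log units; beyond the scatter) as the only measured step on this six-membered aromatic ring, all earlier steps lying on the saturated chain. The read-out therefore responds to a change at this ring carbon as well as to changes in the chain. Nothing available accounts for the size of this step. As far as these compounds go, whether fluoro, methoxy or a carboxylic acid on the same carbon would move the number likewise stays open. So does whether chloro gives a similar step in compound 2, with its 4-methylpiperazin-1-yl chain.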